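A halogen swap in a series held at its limit

The source may report more compounds than this note shows. Statements on the series, on what has been measured and on what is new or still open speak of the compounds shown alone.

Compound 1 `OC[C@H]1O[C@@H](n2cnc3c(NCc4cccc(Br)c4)ncnc32)[C@H](O)[C@@H]1O` gives > 166000 nM as a limit
Compound 2 `Cc1cccc(CNc2ncnc3c2ncn3[C@@H]2O[C@H](CO)[C@@H](O)[C@H]2O)c1` gives > 166000 nM as a limit
Compound 3 `OC[C@H]1O[C@@H](n2cnc3c(NCc4ccc(Cl)c(Cl)c4)ncnc32)[C@H](O)[C@@H]1O` gives > 166000 nM as a limit

In a functional assay on B16 cells (Mus musculus) for antiproliferative activity, with a stated time of 72 h (on this read-out lower numbers stand for stronger inhibition and higher numbers for weaker inhibition), compound 3 reads > 166000 nM as a limit and not a number. The series offers only the limit of > 166000 nM in this assay, at which 3 of the 3 values shown sit, and so no ranking. Compound 4 `OC[C@H]1O[C@@H](n2cnc3c(NCc4ccc(F)c(Cl)c4)ncnc32)[C@H](O)[C@@H]1O` differs from compound 3 by fluoro in place of chloro on an aromatic carbon and carries fluoro in place of chloro on an aromatic carbon. The nearest steps are a step that the two limits leave unreadable from compound 1 to compound 3 and a step that the two limits leave unreadable from compound 2 to compound 3 and neither gives a size. No step beyond the scatter is therefore expected in this assay and no direction can be argued. The expected step is a step that the limit leaves unreadable from compound 3 to compound 4 on this reasoning. For compound 4 the estimated value is 170000 nM with an expected range from 90000 nM to 320000 nM and most likely only a limit will be reported.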

Compound 4, half-maximal inhibitory concentration: 167000 nM
Compound 4: middle estimate off by 1.0-fold (0.01 log units), on the high side; measured number inside the range.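

In this assay compound 4 gives 167000 nM. Among the compounds shown here, compound 1, compound 2 and compound 3 stand only at a limit, so no step to compound 4 can be read. The compounds shown leave any ranking of these four open: the limit of > 166000 nM in this assay, at which 3 of the 4 values shown sit.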